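The source may report more compounds than this note shows. Statements on the series, on what has been measured and on what is new or still open speak of the compounds shown alone.

Of the compounds shown here, three have numbers so far in a functional assay on CHO cells for antagonist activity at prostaglandin E2 receptor EP3 subtype (Homo sapiens), read by cAMP accumulation; a higher number here means a weaker inhibitor, a lower number a stronger inhibitor. Compound 1 `CCn1ncc2c(F)cc(-c3ccc(C(CC)(CC)c4nnc(C)[nH]4)c(=O)[nH]3)cc21` gives 90 nM, the highest of the three. Compound 2 `CC(C)C(c1ccc(-c2ccc3cccc(F)c3c2)[nH]c1=O)N1CCCCC1=O` gives 40 nM, and compound 3 `CC(C)C(Cc1noc(=O)[nH]1)c1ccc(-c2ccc3cccc(F)c3c2)[nH]c1=O` gives 70 nM. Compound 1 stands nearest to compound 3, a gap within the scatter, and furthest from compound 2, a gap beyond the scatter. Among the measured compounds shown here, the only step between measured compounds that differ in one place is a 1.8-fold higher number from compound 2 to compound 3 (0.24 log units; within the scatter), where a five-membered aromatic ring with three hetero atoms replaces a six-membered non-aromatic ring with one hetero atom on a saturated chain carbon bound to an aromatic carbon and a saturated chain carbon.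

Compound 4 `CCn1ncc2c(F)cc(-c3ccc(C(CC)(CC)c4ncn(C)n4)c(=O)[nH]3)cc21` has not been measured. It differs from compound 1 by 1-methyl-1H-1,2,4-triazol-3-yl in place of 5-methyl-4H-1,2,4-triazol-3-yl on a saturated chain carbon bound to an aromatic carbon and two saturated chain carbons; the two compounds hold the same atoms joined differently. For the measured compounds named here, no measured step bears directly on this change: the step from compound 2 to compound 3 sits on a different core and swaps a different pair of groups, and it stayed within the scatter. With no guide of the same kind, only a modest move is expected, in the direction of a higher number. Compound 4 is therefore expected to give 180 nM, between 60 nM and 600 nM, which means a step of a 2.0-fold higher number from compound 1 to compound 4 (0.30 log units; within the scatter).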

Compound 4, half-maximal inhibitory concentration: 96 nM
Compound 4: the middle estimate sits 1.9-fold (0.27 log units) above what was measured; the range from low to high includes it.
By their numbers in this assay, from the lowest: compounds 2, 3, 1 and 4 (each within the scatter of the next, the first and the last beyond it).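

In this assay the two triazole isomers read alike on the core of compound 1, with a 1.1-fold higher number from compound 1 to compound 4 (0.03 log units; within the scatter) for 1-methyl-1H-1,2,4-triazol-3-yl in place of 5-methyl-4H-1,2,4-triazol-3-yl on a saturated chain carbon bound to an aromatic carbon and two saturated chain carbons. Among the compounds shown here, the entering group has 0 hydrogen-bond donors and 3 hydrogen-bond acceptors where the leaving group has 1 donor and 2 acceptors, so at this position the number does not depend on the donor of the leaving group, which the earlier compounds, with no change of this kind on this core, could not show. Nothing measured here accounts for why the two isomers read alike.

The compounds shown leave open how a carboxylic acid or an amine would read in place of the triazole on this same carbon, and whether a longer chain such as propyl in place of the methyl would keep the number. They also leave open whether either triazole would read the same on the core of compound 2.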